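Nucleoside series: benzylsulfanyl step from compound 3 to compound 4

The source may hold more compounds than are shown below. What is called first, only, known or untested is meant among the compounds shown, and "the series" means these compounds.

Compound 1 `Cc1nsc2[nH]c(SCc3ccccc3)nc12` carries the benzylsulfanyl group on the shared core without a sugar. In a functional assay on KB cells (Homo sapiens) for antiproliferative activity (on this read-out higher numbers stand for weaker inhibition and lower numbers for stronger inhibition), compound 1 gives 9000 nM. Compound 2 `Cc1nsc2c1ncn2[C@H]1C[C@H](O)[C@@H](CO)O1` adds the sugar. In this assay compound 2 reaches only a limit, > 100000 nM. Compound 3 `CSc1nc2c(C)nsc2n1[C@H]1C[C@H](O)[C@@H](CO)O1` has methylsulfanyl in place of hydrogen on an aromatic carbon. In this assay compound 3 also reaches only a limit, > 100000 nM. The step that the two limits leave unreadable from compound 2 to compound 3 therefore cannot be read, because of the limit of > 100000 nM in this assay, at which 2 of the 3 values shown sit.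

Compound 3 thus stands at the limit of the measured values, with one further value at the same limit; only compound 1 gives a number.

Compound 4 `Cc1nsc2c1nc(SCc1ccccc1)n2[C@H]1C[C@H](O)[C@@H](CO)O1` is not yet measured. It differs from compound 3 by phenyl in place of hydrogen on a saturated chain carbon bound to a sulfur. Among the compounds with values here, no measured step bears on this change: the one step between measured compounds, from hydrogen to methylsulfanyl, is unreadable, and compound 1 shares the benzylsulfanyl group but not the sugar, so no step is defined between compound 1 and compound 4. With both sugar-bearing compounds at the limit, the step of a number no higher from compound 3 to compound 4 (the limit leaves the size open) is expected to be unreadable or small. For compound 4 the estimate is 100000 nM, with a range from 20000 nM to 300000 nM, and a limit is the likelier result.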

Compound 4, half-maximal inhibitory concentration: > 100000 nM
Compound 4: only a limit was reported; the forecaster's own chance of this, stated with the estimate: 60%; the middle value sits exactly at the limit.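

In this assay, within the data shown here, 4-hydroxy-5-(hydroxymethyl)oxolan-2-yl in place of hydrogen on an aromatic nitrogen gives an at least 11-fold higher number from compound 1 to compound 4 (1.04 log units; beyond the scatter), the first readable step, and it shows that the benzylsulfanyl group does not keep a measurable number once this sugar is attached. Compound 4 reaches only a limit, > 100000 nM, so phenyl in place of hydrogen on a saturated chain carbon bound to a sulfur, the change from methylsulfanyl to benzylsulfanyl, does not bring the sugar-bearing series to a number. The steps to compound 4 from compound 2 and from compound 3 cannot be read, because all three compounds end at the same limit: the limit of > 100000 nM in this assay, at which 3 of the 4 values shown sit.

Going by these compounds, how far compound 4 lies past its limit stays open, so the full size of the sugar step is unknown, and the series holds no sugar-free partner for compound 2 or compound 3. On these data alone, whether an amine or a carboxylic acid in place of the phenyl, or a longer chain on the sulfur, would give a sugar-bearing compound a readable number also remains open.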